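A hydrazide-type replacement on the amide nitrogen

The compounds below may be only part of what the source reports. "The series", "measured", "known", "first", "only" and "open" are said of these compounds alone.

In an assay on isolated protein for inhibition of phosphodiesterase 4A (Sus scrofa) (a lower number here means a stronger inhibitor, a higher number a weaker inhibitor), compound 1 `COc1ccc(C(=O)Nc2ccccc2Cl)cc1OC1CCCC1` gives 190 nM, and compound 2 `COc1ccc(C(=O)Nc2ccncc2)cc1OC1CCCC1` gives 800 nM. Within the data shown here, compound 2 therefore has the higher of the two numbers, the weaker inhibitor, and the only measured step, a 4.2-fold higher number from compound 1 to compound 2 (0.62 log units; beyond the scatter), shows how much was lost when the group on the amide-type nitrogen was exchanged. Compound 3 `COc1ccc(C(=O)NN2C(Cl)=NC=CC2Cl)cc1OC1CCCC1` carries a further exchange at the same place: a group of 8 heavy atoms (4 carbon, 2 nitrogen, 2 chlorine; one six-membered non-aromatic ring with 2 hetero atoms) in place of a group of 6 heavy atoms (5 carbon, 1 nitrogen; one six-membered aromatic ring with 1 hetero atom), on an amide-type nitrogen. Among the measured compounds shown here, the one step that touches this position, from compound 1 to compound 2, was modest in size, so a change of similar or somewhat larger size is plausible, but nothing measured shows its direction for a ring of this kind. An estimated small loss is applied, described by a 1.9-fold higher number from compound 2 to compound 3 (0.27 log units; within the scatter). Compound 3 is expected to give about 1500 nM in this assay, with a range from 400 nM to 6000 nM.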

Compound 3, half-maximal inhibitory concentration: 400 nM
Compound 3: middle estimate off by 3.8-fold (0.57 log units), on the high side, within the range that was stated.
By their numbers in this assay, from the lowest: compound 1; then compounds 3 and 2 (each within the scatter of the next).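

The new ring shows that this place on the amide-type nitrogen accepts more than an aromatic ring: a non-aromatic ring carrying two chlorines, joined through its own nitrogen, cannot be told apart from pyridin-4-yl in this assay, with a 2.0-fold lower number from compound 2 to compound 3 (0.30 log units; within the scatter) lying within the scatter. The 2-chlorophenyl group of compound 1 still holds a small, real edge, as a 2.1-fold higher number from compound 1 to compound 3 (0.32 log units; beyond the scatter) shows, and this edge is beyond the scatter. Nothing available accounts for how these groups compare.

The compounds shown leave open whether the result belongs to the ring or to its chlorines, and the same ring without chlorine, or a plain phenyl, would help to separate the two. Going by these compounds, how a morpholine or a short open chain ending in an amine would fare on this nitrogen also remains unknown.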